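The compounds below may be only part of what the source reports. "The series", "measured", "known", "first", "only" and "open" are said of these compounds alone.

Working notes on the series. In a functional assay on MGC-803 cells (Homo sapiens) for antiproliferative activity, read by CCK-8 assay, with a stated time of 72 h (a higher number here means a weaker inhibitor, a lower number a stronger inhibitor), compound 1 `COc1ccn2c(-c3ccc(NC(=O)c4ccc([N+](=O)[O-])o4)cc3)cnc2c1` gives 860 nM. Compound 2 `COc1ccn2c(-c3ccc(NC(=O)c4ccc([N+](=O)[O-])o4)c(C)c3)cnc2c1` gives 1380 nM in this assay, and compound 3 `COc1ccn2c(-c3ccc(NC(=O)c4ccc([N+](=O)[O-])o4)c(OC)c3)cnc2c1` gives 7520 nM in this assay. The two cores differ by methyl in place of methoxy on an aromatic carbon, a step of a 5.4-fold higher number from compound 2 to compound 3 (0.74 log units; beyond the scatter); the step of a 1.6-fold higher number from compound 1 to compound 2 (0.21 log units; within the scatter) is the other edge of this triangle. Compound 4 `Cc1cc(-c2cnc3ccccn23)ccc1NC(=O)c1ccc([N+](=O)[O-])o1` is not yet measured and differs from compound 2 by hydrogen in place of methoxy on an aromatic carbon. The same kind of change, (hydrogen in place of methoxy on an aromatic carbon), gave an 8.7-fold lower number from compound 3 to compound 1 (0.94 log units; beyond the scatter), but there the place was on a six-membered aromatic ring of carbon only, ortho to a large group and meta to a large group; for compound 4 it is on a six-membered aromatic ring with 1 nitrogen, part of a fused or bridged system of two rings, meta to a fused ring, opposite the ring nitrogen, para to a fused ring. For the measured compounds named here, no measured pair tests this second place, so a smaller step, a 1.4-fold lower number from compound 2 to compound 4 (0.14 log units; within the scatter), is expected from compound 2 to compound 4, with wide uncertainty. Compound 4 is estimated at 1000 nM, between 300 nM and 3500 nM.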

Compound 4, half-maximal inhibitory concentration: 1830 nM
Beside the measured number, compound 4's estimate is 1.8-fold (0.26 log units) below it; measured number inside the range.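

In this assay, hydrogen in place of methoxy does not carry over from one core to the other: the same change on two cores in this assay, an 8.7-fold lower number (0.94 log units; beyond the scatter) from compound 3 to compound 1 and a 1.3-fold higher number (0.12 log units; within the scatter) from compound 2 to compound 4, 12-fold (1.06 log units) apart, beyond the scatter of two such steps. The new step, a 1.3-fold higher number from compound 2 to compound 4 (0.12 log units; within the scatter), lies within the scatter, so at this place on the six-membered aromatic ring with 1 nitrogen the change has no effect that can be read. The two pairs differ both in the place of the change and in the methyl of compound 2 and compound 4, so they do not show which of these accounts for the gap, and they give no mechanism.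

From the compounds shown here alone, it remains open whether an amine or a chlorine atom at this place on the ring with 1 nitrogen would shift the number. Going by these compounds, it is also open how the change would behave at this place on the core of compound 1, which has no methyl.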